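Closing the Alkyne Chain into a Five-Membered Ring

The source may hold more compounds than are shown below. What is called first, only, known or untested is meant among the compounds shown, and "the series" means these compounds.

For the measured compounds named here, compound 2 `COCCC#Cc1c(Cl)c2c(Cl)cc(C(N)=O)nc2n1[C@H]1CCCNC1` gives 643 ng.h/mL in an ADME assay on the whole organism (Rattus norvegicus) for pharmacokinetics, at a dose of 10 mg/kg by the oral route (a higher number here means more compound in the circulation at the dose given, a lower number less compound in the circulation), the lower of the two numbers measured so far, though the only other compound, compound 1 `NC(=O)c1cc(Cl)c2c(Cl)c(C#CC3CCOCC3)n([C@H]3CCCNC3)c2n1` with 979 ng.h/mL, stands within the scatter of it, as the step of a 1.5-fold lower number from compound 1 to compound 2 (0.18 log units; within the scatter) shows. Compound 3 `NC(=O)c1cc(Cl)c2c(Cl)c(C#CC3CCCO3)n([C@H]3CCCNC3)c2n1` has not yet been measured in this assay. It differs from compound 2 in one place: oxolan-2-yl in place of 2-methoxyethyl on a triple-bonded carbon. Going by the values given here, the one measured step that bears on this is the step from compound 1 to compound 2, in which a six-membered oxygen-containing ring on the triple-bonded carbon gave way to the open 2-methoxyethyl chain and the number barely moved. Compound 3 goes the other way, replacing that chain with a five-membered oxygen-containing ring, so no step beyond the scatter is expected: a 1.2-fold higher number from compound 2 to compound 3 (0.09 log units; within the scatter). Compound 3 is therefore estimated at 800 ng.h/mL, within a range from 350 ng.h/mL to 1800 ng.h/mL.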

Compound 3, area under the concentration-time curve: 326 ng.h/mL
Compound 3: middle estimate off by 2.5-fold (0.39 log units), on the high side; the measured number lies below the stated range.
By their numbers in this assay, from the lowest: compounds 3, 2 and 1 (each within the scatter of the next, the first and the last beyond it).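

Going from oxan-4-yl to oxolan-2-yl on the triple-bonded carbon gives a 3.0-fold lower number from compound 1 to compound 3 (0.48 log units; beyond the scatter) in this assay, so the number at this position does depend on which ring is attached, something the earlier pair could not show. With a 2.0-fold lower number from compound 2 to compound 3 (0.29 log units; within the scatter) as the other new step, the open 2-methoxyethyl chain cannot be set apart from the oxolan-2-yl ring, and only the two rings stand clearly apart from each other. The compounds shown leave open whether the ring oxygen matters at all, which a plain cyclopentyl or cyclohexyl group would test. They also leave open how a ring carrying an amine, or a longer ether chain, would fare at this position. No measurement at hand accounts for the gap between the two rings.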